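Swapping the Aryl Amide: From Compound 3 to Compound 4

A few compounds are considered here, and "the series" means these few. Any claim that something is new, unique, unknown or untested is made for them only; others in the source may bear on it.

Three measured compounds share one core and differ only in the aryl group on the carbonyl carbon. Compound 1 `CCN1CCN(c2cc(C)c3cc(NC(=O)c4cccc(Cl)c4)ccc3n2)CC1` gives 17800 nM in a functional assay on SK-BR-3 cells (Homo sapiens) for antiproliferative activity, read by MTT assay, with a stated time of 72 h; a lower number here means a stronger inhibitor, a higher number a weaker inhibitor. Compound 2 `CCN1CCN(c2cc(C)c3cc(NC(=O)c4cccnc4)ccc3n2)CC1` gives 10600 nM in this assay, and compound 3 `CCN1CCN(c2cc(C)c3cc(NC(=O)c4ccc(F)cc4)ccc3n2)CC1` gives 19800 nM in this assay. Compound 3 holds the highest of the three numbers, yet its distances to the other two are within the scatter: a 1.1-fold higher number from compound 1 to compound 3 (0.05 log units; within the scatter) and a 1.9-fold higher number from compound 2 to compound 3 (0.27 log units; within the scatter). Compound 4 `CCN1CCN(c2cc(C)c3cc(NC(=O)c4ccccc4Cl)ccc3n2)CC1` alters the same position once more: 2-chlorophenyl in place of 4-fluorophenyl on a carbonyl carbon Both earlier aryl swaps at this carbonyl carbon left the number within the scatter, so the step of a 1.1-fold lower number from compound 3 to compound 4 (0.04 log units; within the scatter) is expected to stay within the scatter in this assay. Compound 4 is therefore estimated at 18000 nM, with a range from 8000 nM to 40000 nM.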

Compound 4, half-maximal inhibitory concentration: > 50000 nM
Compound 4 was reported as a limit; the forecaster's own chance of this, stated with the estimate: 5%; at least 2.7-fold (0.44 log units) between middle value and limit.
By their numbers in this assay, from the lowest: compounds 2, 1 and 3 (each within the scatter of the next). At a limit, above all of these: compound 4.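

Compound 4 is reported in this assay only as a limit, not as a number: the limit of > 50000 nM in this assay, at which 1 of the 4 values shown sits. Even so, this is the first aryl swap on the carbonyl carbon to go beyond the scatter, with an at least 2.5-fold higher number from compound 3 to compound 4 (0.40 log units; beyond the scatter), an at least 4.7-fold higher number from compound 2 to compound 4 (0.67 log units; beyond the scatter) and an at least 2.8-fold higher number from compound 1 to compound 4 (0.44 log units; beyond the scatter). The position therefore does respond to the aryl group, and 2-chlorophenyl and 3-chlorophenyl are not interchangeable there.

Going by these compounds, the true size of these steps stays open. So does whether 2-fluorophenyl or 2-methoxyphenyl on the same carbonyl carbon would track compound 4 or compounds 1, 2 and 3.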